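Adding a methoxy group to a weak growth inhibitor

The compounds below may be only part of what the source reports. "The series", "measured", "known", "first", "only" and "open" are said of these compounds alone.

Of the compounds shown here, two have been measured so far in a functional assay on MCF7 cells (Homo sapiens) for inhibition, read by CCK-8 assay, with a stated time of 48 h; a higher number here means a weaker inhibitor of growth, a lower number a stronger inhibitor of growth. Compound 1, `Cc1ccccc1Nc1nc(Nc2cccnc2)ncc1Cl`, gives 56500 nM in this assay. Compound 2, `CN1CCN(c2ccc(Nc3ncc(Cl)c(Nc4ccccc4)n3)nc2)CC1`, gives 51800 nM in this assay. Compound 2 has the lower of the two numbers, but its value sits within the scatter of that of compound 1, so the two cannot be told apart; both are weak inhibitors of growth.

Compound 3, `COc1cccc(Nc2nc(Nc3ccc(N4CCN(C)CC4)cn3)ncc2Cl)c1`, is not yet measured. It differs from compound 2 in one place: methoxy in place of hydrogen on an aromatic carbon. Going by the values given here, no pair of measured compounds differing in one place is available. Among the compounds with values here, there is no precedent here for what such a change does in this assay.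

With nothing to anchor the direction, the expected step from compound 2 to compound 3 is a 1.3-fold lower number from compound 2 to compound 3 (0.11 log units; within the scatter), which is within the usual scatter. Compound 3 is therefore estimated to give about 40000 nM in this assay, with a range from 14000 nM to 110000 nM, remaining a weak inhibitor of growth like compound 2.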

Compound 3, concentration for 50% growth inhibition: 7540 nM
The estimate for compound 3 lay 5.3-fold (0.72 log units) above the measured number; measured number outside the range, below it.
By their numbers in this assay, from the lowest: compound 3; then compounds 2 and 1 (each within the scatter of the next).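

Replacing hydrogen with methoxy, which turns the phenyl group of compound 2 into a 3-methoxyphenyl group, gives a 6.9-fold lower number from compound 2 to compound 3 (0.84 log units; beyond the scatter) in this assay; the step is modest but lies beyond the usual scatter. The earlier compounds shown here offered no single-place step, whereas this pair shows that a change of only 2 heavy atoms on this six-membered aromatic ring of carbon only can clearly shift growth inhibition. Nothing available here accounts for the shift, so its cause remains unknown.

On these data alone, this is a single change at a single position, so it remains open whether the shift is particular to methoxy or would also appear with another group in the same place, such as a hydroxyl group, a fluorine atom, or a longer ethoxy chain. As far as these compounds go, it is also open whether methoxy would produce a similar step at another carbon of this ring, or on a compound that differs elsewhere from compound 2.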